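Swapping out the phenyl of compound 1

This account rests on a few compounds, and the source may have more. Where it says the series, first, only, none or still open, it means among the compounds named here.

In an ADME assay on microsomes from liver (Homo sapiens) for metabolic stability (on this read-out lower numbers stand for slow clearance and higher numbers for fast clearance), compound 1 (`Cc1cccnc1N(C(=O)N1CCC(c2ccccc2)CC1)[C@@H]1CCCNC1`) gives < 8 mL.min-1.g-1 as a limit of the assay, not a number. Compound 3 (`Cc1nccnc1N(C(=O)N1CCC(c2ccccc2)CC1)[C@@H]1CCCNC1`) also reports only a limit (< 8 mL.min-1.g-1). Compound 2 (`O=C(N1CCC(c2ccccc2)CC1)N(c1nccc2ccccc12)[C@@H]1CCCNC1`) gives a real number (13.9 mL.min-1.g-1).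

Compound 4 (`Cc1cccnc1N(C(=O)N1CCC(c2cnn3cccnc23)CC1)[C@@H]1CCCNC1`) differs from compound 1 on a saturated ring carbon (a group of 9 heavy atoms (6 carbon, 3 nitrogen; one five-membered aromatic ring with 2 hetero atoms, one six-membered aromatic ring with 2 hetero atoms) in place of a group of 6 heavy atoms (6 carbon; one six-membered aromatic ring of carbon only), on a saturated ring carbon). Within the data shown here, no measured step touches that site. The nearest steps change the group on the amide-type nitrogen instead (an at least 1.7-fold higher number from compound 1 to compound 2 (0.23 log units; that floor lies within the scatter)) and (an at least 1.7-fold lower number from compound 2 to compound 3 (0.23 log units; that floor lies within the scatter)), and both floors lie within the scatter.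

With only these small steps as a guide, no change beyond the scatter is expected in this assay (a number no lower from compound 1 to compound 4 (the limit leaves the size open)). Compound 4 is expected to read about 8 mL.min-1.g-1 (estimated range 5 mL.min-1.g-1 to 15 mL.min-1.g-1).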

Compound 4, intrinsic clearance in microsomes: < 8 mL.min-1.g-1
Compound 4 was reported as a limit; the forecaster's own chance of this, stated with the estimate: 55%; the middle value sits exactly at the limit.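

Compound 1 and compound 4 both report only a limit in this assay, so no step between them can be read: the limit of < 8 mL.min-1.g-1 in this assay, at which 3 of the 4 values shown sit.

The compounds shown leave open whether replacing the phenyl changes clearance at all, and by how much.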